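Swapping a Piperidine Ring for a Dimethylamino Group

The source may report more compounds than this note shows. Statements on the series, on what has been measured and on what is new or still open speak of the compounds shown alone.

Compounds measured so far:
- compound 1, `Cc1ccc2nc(/N=C3\C(=O)N(CN4CCCCC4)c4cccc(Br)c43)sc2c1`, giving 38300 nM
- compound 2, `CN(C)CN1C(=O)C(=O)c2c(Cl)cccc21`, giving 138000 nM
- compound 3, `O=C1C(=O)N(CN2CCCCC2)c2cccc(Cl)c21`, giving 26500 nM

These three numbers come from a functional assay on MDA-MB-231 cells (Homo sapiens) for cytotoxicity, read by sulforhodamine B assay, with a stated time of 48 h; a higher number here means a weaker inhibitor of growth, a lower number a stronger inhibitor of growth. Among them compound 1 stands second highest. Its nearest neighbour is compound 3, whose number sits within the usual scatter of the measurement, so the two cannot be told apart; compound 2 lies clearly higher, beyond that scatter.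

The compound now at issue is compound 4, `Cc1ccc2nc(/N=C3\C(=O)N(CN(C)C)c4cccc(Br)c43)sc2c1`. It keeps everything of compound 1 but for one spot: dimethylamino in place of piperidin-1-yl on a saturated chain carbon bound to an amide-type nitrogen in a ring.

Going by the values given here, only one measured step speaks to this change, and it runs the other way round. Between compound 2 and compound 3, the move a 5.2-fold lower number from compound 2 to compound 3 (0.72 log units; beyond the scatter) replaced dimethylamino by piperidin-1-yl on a different core. Reversing that move on compound 1 is expected to push the number up by a similar amount. The step from compound 1 to compound 4 is therefore estimated at a 3.4-fold higher number from compound 1 to compound 4 (0.53 log units; beyond the scatter). For compound 4 the expected value in this assay is 130000 nM, with a range from 50000 nM to 350000 nM.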

Compound 4, concentration for 50% growth inhibition: 49000 nM
For compound 4 the middle estimate is 2.7-fold (0.42 log units) above the measured one; measured number below the stated range.
By their numbers in this assay, from the lowest: compounds 3, 1 and 4 (each within the scatter of the next); then compound 2.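

The new step in this assay is a 1.3-fold higher number from compound 1 to compound 4 (0.11 log units; within the scatter), which means that on this core piperidin-1-yl and dimethylamino, on a saturated chain carbon bound to an amide-type nitrogen in a ring, cannot be told apart. The ring of piperidin-1-yl, with its larger count of heavy atoms, therefore makes no readable difference here, although the earlier pair of compounds alone had suggested a clear gain from it. The same exchange thus does not carry a fixed size from one core to the other, and the surrounding structure has to be counted in when reading it, as the two steps show: the same change on two cores in this assay, a 5.2-fold lower number (0.72 log units; beyond the scatter) from compound 2 to compound 3 and a 1.3-fold lower number (0.11 log units; within the scatter) from compound 4 to compound 1, 4.1-fold (0.61 log units) apart, beyond the scatter of two such steps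

Going by these compounds, whether other cyclic amines on this carbon, such as morpholin-4-yl or pyrrolidin-1-yl, would also leave the number within the scatter on this core remains open. The two cores differ in more than one place, among them chloro against bromo, and the compounds shown cannot say which of those differences goes with the gap between the two steps.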